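Methyl on the aromatic carbon, carried across two cores

A few compounds are considered here, and "the series" means these few. Any claim that something is new, unique, unknown or untested is made for them only; others in the source may bear on it.

All values come from a functional assay on the whole organism for antagonist activity, with Mus musculus as the target; on this read-out higher numbers stand for an effect only at larger amounts of compound and lower numbers for an effect already at smaller amounts.

Compound 1 `CC(C#CCn1ccnc1)N1CCCC1=O`: in this assay compound 1 gives 2 mg/kg.
Compound 2 `Cc1cncn1CC#CC(C)N1CCCC1=O`: in this assay compound 2 gives 0.45 mg/kg.
Compound 3 `O=C1NCCN1CC#CCn1ccnc1`: in this assay compound 3 reaches only a limit, > 100 mg/kg.

The step from compound 1 to compound 2 is methyl in place of hydrogen on an aromatic carbon, and it gives a 4.4-fold lower number from compound 1 to compound 2 (0.65 log units; beyond the scatter). Compound 3 carries a different core; the difference between the two cores is not broken down here. Of compound 3 only a limit is known, namely (the limit of > 100 mg/kg in this assay, at which 1 of the 3 values shown sits).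

Compound 4 `Cc1cncn1CC#CCN1CCNC1=O` is not yet measured. It differs from compound 3 by methyl in place of hydrogen on an aromatic carbon, the same change as that between compound 1 and compound 2, made on the core of compound 3.

For compound 4 in this assay a step that the limit leaves unreadable from compound 3 to compound 4 is expected, resting on the earlier step of a 4.4-fold lower number from compound 1 to compound 2 (0.65 log units; beyond the scatter), but since compound 3 gave only a limit, a second limit is the more probable outcome. The estimate for compound 4 in this assay is 150 mg/kg, between 25 mg/kg and 1000 mg/kg.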

Compound 4, dose for half-maximal effect: 21 mg/kg
Estimate against measurement, compound 4: 7.1-fold (0.85 log units) above; the measured number lies below the stated range.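

On the core of compound 1 the change gives a 4.4-fold lower number from compound 1 to compound 2 (0.65 log units; beyond the scatter) in this assay, and on the core of compound 3 it gives an at least 4.7-fold lower number from compound 3 to compound 4 (0.67 log units; beyond the scatter). Compound 3 stands only at a limit, > 100 mg/kg, and not at a number. The direction of the step thus carries over in these two pairs, but equal size on the two cores is not shown, and two pairs give no rule for any further core: the same change on two cores in this assay, a 4.4-fold lower number (0.65 log units; beyond the scatter) from compound 1 to compound 2 and an at least 4.7-fold lower number (0.67 log units; beyond the scatter) from compound 3 to compound 4; the limit leaves it open whether they differ

The compounds shown leave open whether ethyl, trifluoromethyl or chlorine in place of the methyl, at the same place on the aromatic ring, would go with a step of the same direction on either core. Also open, going by these compounds, is whether the step would hold with a longer chain in place of the one that links the aromatic ring to the core, or with an amine or a carboxylic acid on the aromatic ring.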